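The source may report more compounds than this note shows. Statements on the series, on what has been measured and on what is new or still open speak of the compounds shown alone.

Compound 1 `O=C(/C=C/c1coc2cc(O)ccc2c1=O)NCc1ccccc1` holds the lower of the two numbers measured in a functional assay on Huh-7 cells (Homo sapiens) for inhibition, read by MTT assay, with a stated time of 48 h (a lower number here means a stronger inhibitor, a higher number a weaker inhibitor), where compound 1 gives 4690 nM. Its nearest neighbour, compound 2 `COc1ccc2c(=O)c(/C=C/C(=O)NCc3ccccc3)coc2c1`, gives 13600 nM in this assay, and the step of a 2.9-fold higher number from compound 1 to compound 2 (0.46 log units; beyond the scatter) corresponds to methyl in place of hydrogen on an oxygen on an aromatic ring. Compound 3 `Cc1ccccc1NC(=O)/C=C/c1coc2cc(O)ccc2c1=O` has not yet been measured. It differs from compound 1 in one place: 2-methylphenyl in place of benzyl on an amide-type nitrogen. Within the data shown here, no measured pair shows an exchange at the amide nitrogen; the only step on record, a 2.9-fold higher number from compound 1 to compound 2 (0.46 log units; beyond the scatter), concerns a different part of the shared core and does not bear on this change. With nothing to lean on, the step of a 1.1-fold higher number from compound 1 to compound 3 (0.03 log units; within the scatter) is expected to stay within or close to the usual scatter, in no clear direction. Compound 3 is therefore estimated at 5000 nM in this assay, with a range from 1500 nM to 17000 nM.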

Compound 3, half-maximal inhibitory concentration: 11100 nM
The estimate for compound 3 lay 2.2-fold (0.35 log units) below the measured number; the range from low to high includes it.
By their numbers in this assay, from the lowest: compound 1; then compounds 3 and 2 (each within the scatter of the next).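

In this assay the exchange of 2-methylphenyl for benzyl on the amide-type nitrogen gives a 2.4-fold higher number from compound 1 to compound 3 (0.37 log units; beyond the scatter) and so shows that the number responds to the group at this position, not only to the methyl on the oxygen of the shared core. The two groups have the same count of heavy atoms and the same six-membered aromatic ring of carbon only, so a modest step appears here with no change in those counts. Nothing available accounts for this step.

Going by these compounds, it remains open whether the step goes with the methyl on the ring or with the change from benzylamino to an amino group bearing the ring directly, a question that phenyl on the same nitrogen could separate. On these data alone, how a longer chain such as 2-phenylethyl, or an amine in that group, would read in this assay also stays unknown.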